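Methyl added on the pyrimidine ring of a thiourea series

The compounds below may be only part of what the source reports. "The series", "measured", "known", "first", "only" and "open" are said of these compounds alone.

Working notes on a small series of thioureas sharing the core of compound 1 `CC(=O)NS(=O)(=O)c1ccc(N/C(S)=N\c2ccnc3cc(C(F)(F)F)ccc23)cc1`. In a functional assay on HepG2 cells (Homo sapiens) for antiproliferative activity, read by sulforhodamine B assay, with a stated time of 48 h (on this read-out higher numbers stand for weaker inhibition and lower numbers for stronger inhibition), compound 1 gives 28400 nM. Compound 2 `Cc1ccnc(NS(=O)(=O)c2ccc(N/C(S)=N\c3ccnc4cc(C(F)(F)F)ccc34)cc2)n1` was recorded in this assay as "not active" (no number reported), and no single number stands for it, so its position on the scale cannot be fixed beyond the statement that inhibition was not detected. Compound 3 `Cc1cc(C)nc(NS(=O)(=O)c2ccc(N/C(S)=N\c3ccnc4cc(C(F)(F)F)ccc34)cc2)n1` differs from compound 2 by methyl in place of hydrogen on an aromatic carbon. Among the measured compounds shown here, no step between measured compounds exists for this change, so the size of the shift in this assay is unknown; given that compound 2 showed no activity, no movement beyond the scatter is expected, and a further report of no activity remains the most likely outcome. Compound 3 is estimated in this assay at 60000 nM, with an expected range from 20000 nM to 200000 nM.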

Compound 3, half-maximal inhibitory concentration: 72200 nM
Compound 3: middle estimate off by 1.2-fold (0.08 log units), on the low side; the range from low to high includes it.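

With this methyl in place of hydrogen on the aromatic carbon, compound 3 gives a number in this assay, whereas compound 2 has none, so substitution here is compatible with measurable inhibition; the step from compound 2 to compound 3 cannot be read. Compound 3 also places the 4,6-dimethylpyrimidin-2-yl group against the acetyl group on the sulfonamide nitrogen, and that exchange weakens inhibition relative to compound 1 (a 2.5-fold higher number from compound 1 to compound 3 (0.41 log units; beyond the scatter)). Nothing on hand bears on why the read-out behaves in this way.

From the compounds shown here alone, whether an ethyl group, a longer chain or an amine at this carbon would give a lower number remains open. Also open, going by these compounds, is whether a carboxylic acid here would keep any measurable inhibition at all.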